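The source may hold more compounds than are shown below. What is called first, only, known or untested is meant among the compounds shown, and "the series" means these compounds.

Measured compounds:
Compound 1, `CCCCN(C)C(=O)CCCOc1cc(OC)c(OC)c2oc(-c3ccc(OC)cc3)c(O)c(=O)c12` — in a functional assay on DLD-1 cells (Homo sapiens) for antiproliferative activity, read by sulforhodamine B assay, with a stated time of 48 h (on this read-out higher numbers stand for weaker inhibition and lower numbers for stronger inhibition), compound 1 gives > 40000 nM, a limit of the assay rather than a number.
Compound 2, `COc1ccc(-c2oc3c(OC)c(OC)cc(OCCCC(=O)N4CCN(C)CC4)c3c(=O)c2O)cc1` — in this assay compound 2 gives > 40000 nM, again only a limit.
Compound 3, `COc1ccc(-c2oc3c(OC)c(OC)cc(OCCCCCC(=O)N4CCN(C)CC4)c3c(=O)c2O)cc1` — in this assay compound 3 gives 13700 nM.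

Compound 2 thus stands at the limit of > 40000 nM in this assay, at which 2 of the 3 values shown sit, and no number is available for it. The step under consideration leads to compound 4, `COc1ccc(-c2oc3c(OC)c(OC)cc(OCCCCCC(=O)NCc4ccccn4)c3c(=O)c2O)cc1`: 2-(((pyridin-2-yl)methyl)carbamoyl)ethyl in place of (4-methylpiperazin-1-yl)carbonyl on a saturated chain carbon, three bonds along the chain from an oxygen on an aromatic ring. Two things change together here: the chain grows, and the amide nitrogen substituent is exchanged. The chain growth alone has been measured, as an at least 2.9-fold lower number from compound 2 to compound 3 (0.46 log units; beyond the scatter) and likewise an at least 2.9-fold lower number from compound 1 to compound 3 (0.46 log units; beyond the scatter), both readable only as a lower bound. The amide exchange between compounds 1 and 2 remains unreadable, a step that the two limits leave unreadable from compound 1 to compound 2. The chain extension is therefore expected to carry compound 4 below the limit into measurable territory, while the amide exchange is expected to add little either way; the expected step is an at least 2.6-fold lower number from compound 2 to compound 4 (0.42 log units; beyond the scatter). For compound 4 the estimate in this assay is 15000 nM, with a range from 5000 nM to 40000 nM.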

Compound 4, half-maximal inhibitory concentration: > 40000 nM
Compound 4 gave a limit, no number; the forecaster's own chance of this, stated with the estimate: 30%; middle value at least 2.6-fold (0.42 log units) from the limit.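

With the longer chain held constant in compound 3 and compound 4, the group on the carbonyl carbon changes the read-out in this assay: ((pyridin-2-yl)methyl)amino in place of 4-methylpiperazin-1-yl gives an at least 2.9-fold higher number from compound 3 to compound 4 (0.46 log units; beyond the scatter). The longer chain alone therefore does not secure a measurable value, and among the compounds shown only compound 3, with the 4-methylpiperazin-1-yl amide, has one. Compound 4 gives only a limit, so the steps to it from compound 1 and compound 2 cannot be read: the limit of > 40000 nM in this assay, at which 3 of the 4 values shown sit.

Still open, going by these compounds, is whether a morpholine amide or a free carboxylic acid at the end of this chain would give a measurable value. Also open, on these data alone, is whether a longer chain carrying the 4-methylpiperazin-1-yl amide would move the value further from that of compound 3.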